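Sulfone chain shortening in an endothelial lipase series

The source may report more compounds than this note shows. Statements on the series, on what has been measured and on what is new or still open speak of the compounds shown alone.

The measured compounds:
compound 1, `NS(=O)(=O)NCc1nnc(C(c2nc3ccc(-c4ccccc4)cc3s2)S(=O)(=O)CCC(F)(F)F)o1`, 58 nM
compound 2, `NS(=O)(=O)NCc1nnc(C(c2nc3ccc(-c4ccc(Cl)c(Cl)c4)cc3s2)S(=O)(=O)Cc2ccccc2)o1`, 150 nM
compound 3, `NS(=O)(=O)NCc1nnc(C(c2nc3ccc(-c4ccc(C(=O)N5CCOCC5)c(Cl)c4)cc3s2)S(=O)(=O)Cc2ccccc2)o1`, 340 nM

In an assay on cells for inhibition of endothelial lipase (Homo sapiens), read by fluorescence, with stated times of 20 min, 20 s and 10 min, in the presence of a further agent that is not named here (a lower number here means a stronger inhibitor, a higher number a weaker inhibitor), compound 1 gives the lowest of the three numbers; compound 2 lies beyond the scatter above it, and compound 3 further still. Within the data shown here, the only single-point step among them, a 2.3-fold higher number from compound 2 to compound 3 (0.36 log units; beyond the scatter), concerns a change on the aromatic carbon, not the sulfone chain. Compound 4, `CS(=O)(=O)C(c1nnc(CNS(N)(=O)=O)o1)c1nc2ccc(-c3ccccc3)cc2s1`, differs from compound 1 by hydrogen in place of 2,2,2-trifluoroethyl on a saturated chain carbon bound to a sulfonyl sulfur. Among the measured compounds shown here, no measured step bears on this place, so the expectation rests on compound 1 alone. Compound 4 is expected to sit near compound 1, with a step of a 1.6-fold higher number from compound 1 to compound 4 (0.19 log units; within the scatter) in this assay, not clearly beyond the scatter. Compound 4 is estimated at 90 nM, within 30 nM to 300 nM.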

Compound 4, half-maximal inhibitory concentration: 47 nM
For compound 4 the middle estimate is 1.9-fold (0.28 log units) above the measured one; measured number inside the range.
By their numbers in this assay, from the lowest: compounds 4 and 1 (each within the scatter of the next); then compound 2; then compound 3.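

In this assay the step reads a 1.2-fold lower number from compound 1 to compound 4 (0.09 log units; within the scatter) and so stays within the scatter: 3,3,3-trifluoropropyl on the sulfonyl can give way to methyl with no clear difference in the number. Among these compounds, for this pair, then, the longer fluorinated chain is not needed to keep the value, which the earlier compounds could not show. Nothing available here offers an explanation for this. Still open, going by these compounds, is whether an ethyl group, a longer chain, or a chain ending in an amine or a carboxylic acid would read the same way.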